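Carboxy to pyridin-3-yl on the chlorinated aryl ring

A few compounds are considered here, and "the series" means these few. Any claim that something is new, unique, unknown or untested is made for them only; others in the source may bear on it.

Compound 1 `Cn1c(-c2ccc(N)cc2Cl)nnc1C1(c2ccc(Cl)cc2)CCC1` and compound 2 `Cn1c(-c2ccc(C(=O)O)cc2Cl)nnc1C1(c2ccc(Cl)cc2)CCC1` share one core. In a functional assay on the whole organism (strain ICR) for inhibition, with Mus musculus as the target, read by scintillation counting, with a stated time of 16 h, at a dose of 10 mg/kg by the oral route (a lower number here means less inhibition, a higher number more inhibition at the dose given (going by the name of the read-out)), compound 1 gives 38% and compound 2 gives 38%, so the step of no change at the digits printed from compound 1 to compound 2 (within the scatter) left the read-out unchanged, and compound 2 stands level with compound 1. Compound 3 `Cn1c(-c2ccc(-c3cccnc3)cc2Cl)nnc1C1(c2ccc(Cl)cc2)CCC1` carries the change (pyridin-3-yl in place of carboxy on an aromatic carbon). For the measured compounds named here, the only known step shows that exchanging one small group for another at this place moved nothing. Going by the values given here, a larger aromatic group now enters, which no measured step covers, so only a modest shift in either direction is expected, giving a number 2 percentage points higher from compound 2 to compound 3 (within the scatter). Compound 3 is estimated at 40%, between 20% and 60%.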

Compound 3, a percentage reported as inhibition, in the whole organism at one dose (the size of the read-out at that dose, not a potency): 26%
Compound 3: middle estimate off by 14 percentage points, on the high side, within the range that was stated.
By their numbers in this assay, from the lowest: compound 3; then compounds 1 and 2 (each within the scatter of the next).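

In this assay, putting pyridin-3-yl in place of carboxy gives a number 12 percentage points lower from compound 2 to compound 3 (beyond the scatter), and putting it in place of amino gives a number 12 percentage points lower from compound 1 to compound 3 (beyond the scatter). The read-out at this position can therefore change with the group it carries, which the level pair of compound 1 and compound 2 could not show. Nothing measured here explains the drop. Still open, from the compounds shown here alone, is whether a phenyl ring, which has carbon atoms only, or a pyridin-4-yl group would read like pyridin-3-yl, and how a small methyl group would compare.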